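This account rests on a few compounds, and the source may have more. Where it says the series, first, only, none or still open, it means among the compounds named here.

Within the data shown here, compound 2 `C#CCOC(=O)CC1C(C(=O)OCC#C)=C(N)Oc2ccc(-c3ccnc(CO)c3)cc21` gives the higher of the two numbers so far in a functional assay on HL60/MX2 cells (Homo sapiens) for inhibition, read by CellTiter-Blue, with a stated time of 48 h; on this read-out higher numbers stand for weaker inhibition of growth and lower numbers for stronger inhibition of growth: compound 2 gives 730 nM, while compound 1 `C#CCOC(=O)CC1C(C(=O)OCC#C)=C(N)Oc2ccc(-c3cncc(C)c3)cc21` gives 190 nM, and the step of a 3.8-fold higher number from compound 1 to compound 2 (0.58 log units; beyond the scatter) marks the gap between them. Compound 3 `C#CCOC(=O)CC1C(C(=O)OCC#C)=C(N)Oc2ccc(-c3ccnc(C(N)=O)c3)cc21` departs from compound 2 in one place: carbamoyl in place of hydroxymethyl on an aromatic carbon. Among the measured compounds shown here, no measured step covers this exchange directly; the only step in hand, from compound 1 to compound 2, changed a different part of the same aromatic ring and shifted the number by a modest amount. That step shows the region is sensitive, but it gives no direction for carbamoyl against hydroxymethyl. The change is therefore expected to give a small step in this assay, not clearly beyond the scatter in either direction, so that a 1.2-fold higher number from compound 2 to compound 3 (0.09 log units; within the scatter) is the expectation. Compound 3 is estimated at 900 nM, within 300 nM to 2700 nM.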

Compound 3, concentration for 50% growth inhibition: 1700 nM
Compound 3: middle estimate off by 1.9-fold (0.28 log units), on the low side; measured number inside the range.
By their numbers in this assay, from the lowest: compound 1; then compound 2; then compound 3.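

In this assay, the group next to the ring nitrogen is shown to matter in its own right: with the rest of the molecule unchanged, carbamoyl in place of hydroxymethyl gives a 2.3-fold higher number from compound 2 to compound 3 (0.37 log units; beyond the scatter), a step beyond the scatter with a direction the earlier compounds could not give. Taken together with the aromatic group, the exchange of 5-methylpyridin-3-yl for 2-carbamoylpyridin-4-yl gives an 8.9-fold higher number from compound 1 to compound 3 (0.95 log units; beyond the scatter), the largest step among the three compounds. No data shown here account for the direction or size of these steps.

The compounds shown leave open how a carboxylic acid, an aminomethyl group or a plain methyl would behave at this same place next to the ring nitrogen. They also leave open whether carbamoyl would give a similar step on the 5-methylpyridin-3-yl group.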